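Carboxymethyl on the ring nitrogen: expected cytotoxicity

The source may hold more compounds than are shown below. What is called first, only, known or untested is meant among the compounds shown, and "the series" means these compounds.

Working notes on two measured compounds and one awaiting a result. For the measured compounds named here, compound 1 `COc1cc(OC)c2cc(-c3ccccc3)c(O)nc2c1` is the first entry of the series. In a functional assay on A549 cells (Homo sapiens) for cytotoxicity, read by colorimetric assay and MTT assay (on this read-out higher numbers stand for weaker inhibition and lower numbers for stronger inhibition), compound 1 gives 10000 nM. Compound 2 `COc1ccc(-c2cc3c(OC)cc(OC)cc3n(C)c2=O)cc1` is the second entry, and in this assay compound 2 gives 10000 nM. Compound 2 stands level with compound 1 at the digits shown, the two values lying within the scatter of each other; no ordering between the two can be read from these numbers, and neither is to be called the more or less potent.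

The step to compound 3 `COc1ccc(-c2cc3c(OC)cc(OC)cc3n(CC(=O)O)c2=O)cc1` is: carboxy in place of hydrogen on a saturated chain carbon bound to an aromatic nitrogen. Cut one bond further out, the same change reads methyl to carboxymethyl. Going by the values given here, no measured pair shows the effect of this kind of change, so the expectation rests only on the two values at hand and their flat picture. In this assay the step expected is no change at the digits printed from compound 2 to compound 3 (within the scatter), which is to say none beyond the scatter. For compound 3 the estimate in this assay is 10000 nM, with a range from 5000 nM to 20000 nM.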

Compound 3, half-maximal inhibitory concentration: 10000 nM
Estimate against measurement, compound 3: no gap at the digits printed; measured number inside the range.
By their numbers in this assay, from the lowest: compounds 1, 2 and 3 (each within the scatter of the next).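

Carboxy in place of hydrogen on a saturated chain carbon bound to an aromatic nitrogen, which also reads as methyl to carboxymethyl, gives no change at the digits printed from compound 2 to compound 3 (within the scatter) in this assay. For the compounds shown here, the earlier compounds offered no pair differing in one place, so this is the first single change that can be read: at this position, carboxy with its 3 heavy atoms enters with no difference beyond the scatter. No measurement is at hand that bears on the reason for this level result.

From the compounds shown here alone, whether an amine, an amide or a longer chain carrying the carboxy group at this position would also stay level with compound 2 remains open. This one step also says nothing about changes elsewhere on the shared core, or about whether the same change would read alike on a compound with a different value in this assay.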